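A propargyl swap on the core of compound 1

The compounds below may be only part of what the source reports. "The series", "measured", "known", "first", "only" and "open" are said of these compounds alone.

- compound 1 `CCOC(=O)C(C)Oc1c(Br)cc(Br)cc1Oc1ccc(Br)cc1Br`: 39.5 ug/mL
- compound 2 `Brc1ccc(Oc2cc(Br)cc(Br)c2OCCCCCN2CCN(C/C=C/c3ccccc3)CC2)c(Br)c1`: 32.7 ug/mL

In a functional assay on U-937 cells (Homo sapiens) for cytotoxicity, read by MTT assay, with a stated time of 24 h (on this read-out higher numbers stand for weaker inhibition and lower numbers for stronger inhibition), compound 1 gives 39.5 ug/mL, within the scatter of compound 2 at 32.7 ug/mL. Compound 3 `C#CCOc1c(Br)cc(Br)cc1Oc1ccc(Br)cc1Br` keeps the core of compound 1 and changes one place: propargyl in place of 1-(ethoxycarbonyl)ethyl on an oxygen on an aromatic ring, with propargyl in place of 1-(ethoxycarbonyl)ethyl on an oxygen on an aromatic ring. Within the data shown here, no measured step tests this change, and the two values give no direction, so no step beyond the scatter is expected in this assay. The estimated change is a 1.2-fold lower number from compound 1 to compound 3 (0.09 log units; within the scatter). For compound 3 the expected value is 32 ug/mL, with an estimated range from 14 ug/mL to 70 ug/mL.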

Compound 3, half-maximal inhibitory concentration: 29.5 ug/mL
The estimate for compound 3 lay 1.1-fold (0.04 log units) above the measured number, and the stated range covers the measured number.
By their numbers in this assay, from the lowest: compounds 3, 2 and 1 (each within the scatter of the next).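

In this assay putting propargyl in place of 1-(ethoxycarbonyl)ethyl on an oxygen on an aromatic ring gives a 1.3-fold lower number from compound 1 to compound 3 (0.13 log units; within the scatter) as the first step read at this position. The oxygen substituent can thus go from the larger group with its hydrogen-bond acceptors to propargyl, which has fewer heavy atoms and no hydrogen-bond acceptors, with no step beyond the scatter. No measurement shown bears on why this is so.

From the compounds shown here alone, whether an amine, a carboxylic acid or a longer unbranched ester on this oxygen would give a step beyond the scatter stays open.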